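The source may report more compounds than this note shows. Statements on the series, on what has been measured and on what is new or still open speak of the compounds shown alone.

The account starts from two compounds that share a core and differ in one group. In an ADME assay on microsomes from liver (Mus musculus) for metabolic stability, read by LC-MS, with NADPH named in the record, with a stated time of 60 min, tested at 1 uM, in the absence of a further agent (a higher number here means that more of the compound is left, a lower number that less of the compound is left), compound 1 (`CC(=O)N[C@@H]1CCN(c2cc(C)nn3c(-c4ccco4)c(C)nc23)C1`) gives > 95%, which is a limit of the assay and not a number. Compound 2 (`CC(=O)N[C@@H]1CCN(c2cc(C)nn3c(-c4nccs4)c(C)nc23)C1`) gives > 95%, likewise a limit, and the step followed here starts from there. Compound 3 (`CC(=O)N[C@@H]1CCN(c2cc(C)nn3c(-c4ccc5cc[nH]c5c4)c(C)nc23)C1`) differs from compound 2 in a single place on an aromatic carbon: 1H-indol-6-yl in place of 1,3-thiazol-2-yl on an aromatic carbon. Within the data shown here, only one measured step bears on this change, a step that the two limits leave unreadable from compound 1 to compound 2, and it offers no size to carry over. The evidence amounts to the limit of > 95% in this assay, at which 2 of the 2 values shown sit. Among the measured compounds shown here, no measured compound carries 1H-indol-6-yl, and this exchange is larger by count than the one between the two measured groups. A fall in this assay is therefore expected, although its size is poorly constrained, and the estimated change is a number at least 25 percentage points lower from compound 2 to compound 3 (beyond the scatter). Compound 3 is expected to give about 70%, with an estimated range from 40% to 95%.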

Compound 3, percent of the compound remaining: > 95%
Compound 3: a limit, no number (the forecaster's own chance of this, stated with the estimate: 20%); middle value at least 25 percentage points from the limit.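

In this assay compound 3 gives > 95%, a limit and not a number. No step among compound 1, compound 2 and compound 3 can be read: the limit of > 95% in this assay, at which 3 of the 3 values shown sit.

The compounds shown leave open whether furan-2-yl, 1,3-thiazol-2-yl and 1H-indol-6-yl differ at all in this assay, and which change on the shared core would lower the percent of compound remaining.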